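The compounds below may be only part of what the source reports. "The series", "measured", "known", "first", "only" and "open" are said of these compounds alone.

Working notes on the sulfonylurea series.

Three compounds have been run in a functional assay on the whole organism (blood) with Rattus norvegicus as the target, with stated times of 24 h and 1 h, at a dose of 5 mg/kg by the intraperitoneal route; on this read-out higher numbers stand for a stronger effect at the one dose given and lower numbers for a weaker effect. Compound 1 `COc1ccc(Cl)cc1C(=O)NCC1CCN(S(=O)(=O)NC(=O)NC[C@@H]2C[C@@H]3C=C[C@@H]2C3)CC1` gives 15%. Compound 2 `CCCCCCNC(=O)NS(=O)(=O)N1CCC(CNC(=O)c2cc(Cl)ccc2OC)CC1` gives 17%. Compound 3 `COc1ccc(Cl)cc1C(=O)NCCC1CCN(S(=O)(=O)NC(=O)NC2CCCCC2)CC1` gives 25%. Compound 3 returns the largest of the three numbers, but its gap to compound 2 and its gap to compound 1 both fall inside the scatter of this read-out, so no ordering among the three is supported.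

Within the data shown here, the one measured single-point step is a number 2 percentage points higher from compound 1 to compound 2 (within the scatter), a swap at the urea end of the molecule that moved nothing beyond the scatter.

Compound 4 `COc1ccc(Cl)cc1C(=O)NCCC1CCN(S(=O)(=O)NC(=O)NC[C@@H]2C[C@@H]3C=C[C@@H]2C3)CC1` is the next candidate. It differs from compound 3 by a group of 8 heavy atoms (8 carbon; 2 five-membered non-aromatic rings of carbon only) in place of a group of 6 heavy atoms (6 carbon; one six-membered non-aromatic ring of carbon only), on an amide-type nitrogen. This is again a change confined to the group on the urea nitrogen, and it is the same bicyclic group whose removal in the step from compound 1 to compound 2 left the read-out flat. Among the measured compounds shown here, the only bearing evidence therefore points to no step beyond the scatter in this assay, with direction undetermined.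

Compound 4 is expected to give 21%, between 8% and 34%, an estimated step of a number 4 percentage points lower from compound 3 to compound 4 (within the scatter).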

Compound 4, a percentage reported as activity, at one dose (the size of the read-out at that dose, not a potency): 37%
Beside the measured number, compound 4's estimate is 16 percentage points below it; the whole stated range lies below it.
By their numbers in this assay, from the lowest: compounds 1, 2 and 3 (each within the scatter of the next); then compound 4.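

In this assay, the group on this amide-type nitrogen now shows a modest but real effect: a number 12 percentage points higher from compound 3 to compound 4 (beyond the scatter) when cyclohexyl gives way to the group of 8 carbon with 2 five-membered non-aromatic rings. Among these compounds, the earlier step at the urea end, a number 2 percentage points higher from compound 1 to compound 2 (within the scatter), stayed within the scatter, so this is the first change at this end of the molecule to move the read-out beyond it, and the finding rests on this single pair. No measurement at hand accounts for the size or the direction of the step.

The entering group differs from cyclohexyl at once in its ring system, its double bond and its 3 defined stereocentres, so the compounds shown leave open which of these features goes with the higher number. A cyclohexylmethyl group, or the fully saturated version of the bicyclic group on the core of compound 4, would separate these features, and the mirror-image form of the bicyclic group would test whether its defined stereocentres matter.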